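A few compounds are considered here, and "the series" means these few. Any claim that something is new, unique, unknown or untested is made for them only; others in the source may bear on it.

In a functional assay on MCF7 cells (Homo sapiens) for cytotoxicity, read by MTT assay, with a stated time of 48 h (a lower number here means a stronger inhibitor, a higher number a weaker inhibitor), compound 3 `C/C(=N/NC(=S)Nc1cccc([N+](=O)[O-])c1)c1ccccn1` gives 38 nM, the highest number among the three measured compounds, shared with compound 1. Compound 1 `C/C(=N\NC(=S)Nc1cccc([N+](=O)[O-])c1)c1ccccn1` gives 38 nM, and the step of no change at the digits printed from compound 1 to compound 3 (within the scatter) fits with the fact that compounds 1 and 3 differ only in the configuration as drawn. Compound 2 `CC(=NNC(S)=Nc1ccccc1Cl)c1ccccn1` gives 0.16 nM, far below both. Compound 4 `C/C(=N/NC(=S)Nc1cccc(F)c1)c1ccccn1` has not yet been measured in this assay. It differs from compound 3 by fluoro in place of nitro on an aromatic carbon. Going by the values given here, none of the measured steps swaps one substituent for another on that ring, so the only direct guide is the unchanged pair of compound 1 and compound 3, which says nothing about this exchange. Compound 4 is therefore expected near compound 3, at 40 nM within 5 nM to 400 nM, an expected step of a 1.1-fold higher number from compound 3 to compound 4 (0.02 log units; within the scatter) that may well lie within the scatter.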

Compound 4, half-maximal inhibitory concentration: 9 nM
Beside the measured number, compound 4's estimate is 4.4-fold (0.65 log units) above it; the range from low to high includes it.
By their numbers in this assay, from the lowest: compound 2; then compound 4; then compounds 1 and 3 (each within the scatter of the next).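

Going by these compounds alone, until this result, the only step between measured compounds changed configuration alone, so nothing showed whether the substituent on this aromatic carbon matters. Fluoro in place of nitro gives a 4.2-fold lower number from compound 3 to compound 4 (0.63 log units; beyond the scatter), so this place, meta to a large group, does respond to the choice of substituent, though the step is modest. Nothing in the available evidence accounts for the size or direction of this step. Open, from the compounds shown here alone, is how other groups at this same place would compare, such as an amine, a carboxylic acid or a longer chain. Also open, going by these compounds, is whether fluoro behaves the same with the double bond drawn the other way.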